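This account rests on a few compounds, and the source may have more. Where it says the series, first, only, none or still open, it means among the compounds named here.

In a functional assay on L1210 cells (Mus musculus) for inhibition (on this read-out lower numbers stand for stronger inhibition and higher numbers for weaker inhibition), compound 1 (`C#CCN(Cc1ccc2nc(C)nc(O)c2c1)c1ccccc1`) stands at > 6500 nM, which is a limit and not a number. Compound 4 (`C#CCN(Cc1ccc2nc(C)nc(O)c2c1)c1ccc([N+](=O)[O-])cc1`) differs from it by nitro in place of hydrogen on an aromatic carbon, with nitro in place of hydrogen, para to a large group. Two measured changes on the same ring offer a guide. Compound 2 (`C#CCN(Cc1ccc2nc(C)nc(O)c2c1)c1cccc(CC)c1`) gives 5000 nM. Adding ethyl there is an at least 1.3-fold lower number from compound 1 to compound 2 (0.11 log units; that floor lies within the scatter). Compound 3 (`C#CCN(Cc1ccc2nc(C)nc(O)c2c1)c1cccc(C#C)c1`) gives > 2400 nM, which is also a limit. Adding ethynyl there is a step that the two limits leave unreadable from compound 1 to compound 3. Among the compounds with values here, this offers no large step as a precedent, so only a small shift towards a lower number is expected, with the estimate being an at least 1.3-fold lower number from compound 1 to compound 4 (0.11 log units; that floor lies within the scatter). Compound 4 is expected to give 5000 nM, within an estimated range of 1500 nM to 16000 nM.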

Compound 4, half-maximal inhibitory concentration: 4700 nM
For compound 4 the middle estimate is 1.1-fold (0.03 log units) above the measured one, within the range that was stated.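

In this assay, nitro para to a large group gives an at least 1.3-fold lower number from compound 1 to compound 4 (0.14 log units; that floor lies within the scatter), so this place on the ring carries a group of 3 heavy atoms with no loss of inhibition. This is the only change shown at this place. The true size of the step cannot be read because compound 1 has only a limit: the limit of > 6500 nM in this assay, at which 1 of the 4 values shown sits.

From the compounds shown here alone, whether an amine or a carboxylic acid at this place would give a clearly lower or higher number stays open. So does how nitro would behave at the place that ethyl holds in compound 2.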